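From 2-ethylphenyl to 3-chlorophenyl on the oxygen

A few compounds are considered here, and "the series" means these few. Any claim that something is new, unique, unknown or untested is made for them only; others in the source may bear on it.

In a functional assay on MCF7 cells (Homo sapiens) for antiproliferative activity, read by sulforhodamine B assay, with a stated time of 48 h (on this read-out lower numbers stand for stronger inhibition and higher numbers for weaker inhibition), compound 1 (`CCc1ccccc1OS(=O)(=O)c1ccc(N2CCN(C)C2=O)cc1`) gives 26000 nM as its value. Compound 2 (`CCN1CCN(c2ccc(S(=O)(=O)Oc3cccc(Br)c3)cc2)C1=O`) gives 2500 nM and compound 3 (`CCCN1CCN(c2ccc(S(=O)(=O)Oc3ccccc3CC)cc2)C1=O`) gives 2300 nM on the same read-out, so these two lie within the scatter of each other and share the low end of the three numbers.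

Compound 4 (`CCCN1CCN(c2ccc(S(=O)(=O)Oc3cccc(Cl)c3)cc2)C1=O`) is still unmeasured. It keeps the rest of compound 3 but has 3-chlorophenyl in place of 2-ethylphenyl on an oxygen. Among the compounds with values here, the one measured step is large (an 11-fold lower number from compound 1 to compound 3 (1.05 log units; beyond the scatter)) but concerns the chain on the amide-type nitrogen, not the group on this oxygen, so it offers little guidance here. Compound 4 has chlorine where compound 2 has bromine, and compound 2 stands at 2500 nM with a different chain. In this assay no change beyond the scatter is therefore expected, with a 1.2-fold lower number from compound 3 to compound 4 (0.06 log units; within the scatter) as the estimated step. For compound 4 the estimate is 2000 nM with an expected range from 700 nM to 6000 nM on this read-out.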

Compound 4, half-maximal inhibitory concentration: 380 nM
For compound 4 the middle estimate is 5.3-fold (0.72 log units) above the measured one, outside the stated range (below it).
By their numbers in this assay, from the lowest: compound 4; then compounds 3 and 2 (each within the scatter of the next); then compound 1.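

The group on the oxygen bound to the sulfonyl sulfur clearly matters in this assay: with the rest of the molecule unchanged, 3-chlorophenyl in place of 2-ethylphenyl gives a 6.1-fold lower number from compound 3 to compound 4 (0.78 log units; beyond the scatter) on this read-out. The earlier step, an 11-fold lower number from compound 1 to compound 3 (1.05 log units; beyond the scatter), concerned the chain on the amide-type nitrogen, so two separate places on these compounds have now been shown to move the number beyond the scatter. Nothing at hand explains why this swap on the oxygen lowers the number.

The names 2-ethylphenyl and 3-chlorophenyl differ both in the group carried and in where it sits, and the compounds shown do not separate these two changes. As far as these compounds go, how 2-chlorophenyl or 3-ethylphenyl would read on the oxygen, with the chain of compound 4 kept, remains open.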